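Cyclopropane acid variants in a mouse fatty acid receptor series

A few compounds are considered here, and "the series" means these few. Any claim that something is new, unique, unknown or untested is made for them only; others in the source may bear on it.

Measured compounds:
- compound 1 `Cc1nn(-c2ccccn2)c2cc(-c3ccc(CC(C)(C)C(=O)O)cc3)ccc12`; in a functional assay on cells for agonist activity at Free fatty acid receptor 1 (Mus musculus), read by FLIPR and calcium flux, with a stated time of 5 min (on this read-out lower numbers stand for an effect already at smaller amounts and higher numbers for an effect only at larger amounts of compound), compound 1 gives > 100000 nM, a limit of the assay.
- compound 2 `CCc1nn(-c2ccccn2)c2cc(-c3ccc(CCC(=O)O)cc3)ccc12`; in this assay compound 2 gives 1100 nM.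
- compound 3 `Cc1nn(-c2ccccn2)c2cc(-c3ccc([C@H]4C[C@@H]4C(=O)O)cc3)ccc12`; in this assay compound 3 gives > 100000 nM; > 100000 nM (2 entries), both entries limits of the assay.

Compound 1 stands only at a limit, the point where one of the three values sits (the limit of > 100000 nM in this assay, at which 1 of the 3 values shown sits). The step to compound 4 `Cc1nn(-c2ccccn2)c2cc(-c3ccc([C@H]4C[C@H]4C(=O)O)cc3)ccc12` is 2-carboxycyclopropyl in place of 2-carboxy-2-methylpropyl on an aromatic carbon. Compound 4 differs from compound 3 only at its two defined stereocentres, and compound 3 sits at the same limit. With both neighbours at the limit, the step from compound 1 to compound 4 is expected to stay near the limit, any gain being uncertain; the estimate for compound 4 is 40000 nM, between 3000 nM and 300000 nM, an expected step of an at least 2.5-fold lower number from compound 1 to compound 4 (0.39 log units; beyond the scatter).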

Compound 4, half-maximal effective concentration: 19000 nM
For compound 4 the middle estimate is 2.1-fold (0.32 log units) above the measured one; the range from low to high includes it.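

In this assay, 2-carboxycyclopropyl in place of 2-carboxy-2-methylpropyl on an aromatic carbon gives an at least 5.2-fold lower number from compound 1 to compound 4 (0.72 log units; beyond the scatter), a step read against a limit and therefore without a fixed size. Compound 3 stays at a limit of the assay, > 100000 nM; > 100000 nM (2 entries). Compound 4 gives 19000 nM. The drawn configuration of the ring is thus all that separates the results of these two compounds: the fact that compounds 3 and 4 differ only in the configuration as drawn

Open, as far as these compounds go, is whether a cyclobutane ring carrying the acid would read like the cyclopropane of compound 4 in this assay. Also open, from the compounds shown here alone, is how a tetrazole in place of the carboxylic acid would read there.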